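The compounds below may be only part of what the source reports. "The series", "measured", "known", "first", "only" and "open" are said of these compounds alone.

Compound 1 `CC(C)(O)c1ccc(C(=O)NCc2ccc(NS(C)(=O)=O)cc2Cl)cc1`: 32 nM in an assay on HeLa cells for agonist activity at Bile acid receptor (Homo sapiens), read by a luciferase reporter, with a stated time of 24 h; on this read-out lower numbers stand for an effect already at smaller amounts and higher numbers for an effect only at larger amounts of compound
Compound 2 `CC(F)(F)c1ccc(C(=O)NCc2ccc(NS(C)(=O)=O)cc2Cl)cc1`: 1200 nM in this assay

For the measured compounds named here, compound 2 holds the highest of these two numbers; the only neighbour, compound 1, sits far lower, and the step of a 38-fold higher number from compound 1 to compound 2 (1.57 log units; beyond the scatter) is large. Compound 3 `CS(=O)(=O)Nc1ccc(CNC(=O)c2ccc(C(F)(F)C(F)(F)F)cc2)c(Cl)c1` has not yet been measured. It differs from compound 2 by trifluoromethyl in place of methyl on a saturated chain carbon bound to an aromatic carbon and two fluorine atoms. Going by the values given here, no measured step matches this exchange. Among the compounds with values here, the one known step, a 38-fold higher number from compound 1 to compound 2 (1.57 log units; beyond the scatter), replaced a 1-hydroxy-1-methylethyl with a 1,1-difluoroethyl, a different change, and it bears on the present one only by showing that alterations at this place can move the number strongly. Without a closer guide, compound 3 is expected to stay near compound 2, and compound 3 is expected to show a 1.3-fold higher number from compound 2 to compound 3 (0.12 log units; within the scatter), leaning slightly toward higher numbers. Compound 3 is therefore estimated at 1600 nM, with a range from 400 nM to 6500 nM.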

Compound 3, half-maximal effective concentration: 3220 nM
Compound 3: the middle estimate sits 2.0-fold (0.30 log units) below what was measured, and the stated range covers the measured number.
By their numbers in this assay, from the lowest: compound 1; then compound 2; then compound 3.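

Replacing methyl with trifluoromethyl on the saturated chain carbon turns 1,1-difluoroethyl into 1,1,2,2,2-pentafluoroethyl and brings a 2.7-fold higher number from compound 2 to compound 3 (0.43 log units; beyond the scatter) in this assay. This shows that a change at the outer end of this group still moves the number beyond the scatter, though far less than the earlier step did. Against the 1-hydroxy-1-methylethyl, the same group gives a 100-fold higher number from compound 1 to compound 3 (2.00 log units; beyond the scatter), so both fluorinated groups shown stand well above that group, and nothing shown gives a reason for either step.

As far as these compounds go, it remains open which part of the 1-hydroxy-1-methylethyl goes with the low number of compound 1. A hydroxymethyl, an amine or a carboxylic acid in this place could show whether other groups reach a similarly low number.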